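The source may hold more compounds than are shown below. What is called first, only, known or untested is meant among the compounds shown, and "the series" means these compounds.

Series notes. Compound 1 `CCCn1c(=O)[nH]c2nc(-c3ccc(S(=O)(=O)N4CCN(c5ccccc5C)CC4)cc3)[nH]c2c1=O` was run in an assay on CHO cells for displacement of a labelled ligand from adenosine receptor A3 (Homo sapiens), read by scintillation counting, with a stated time of 45 min, in the presence of a further agent that is not named here; on this read-out lower numbers stand for stronger inhibition and higher numbers for weaker inhibition. In this assay compound 1 returns only a limit, > 1000 nM, and not a number. Compound 2 `CCCn1c(=O)c2[nH]c(-c3ccc(S(=O)(=O)N4CCN(c5ccc(Cl)cc5)CC4)cc3)nc2n(CC)c1=O` also returns in this assay only the limit > 1000 nM. Compound 3 `CCCn1c(=O)[nH]c2nc(-c3ccc(S(=O)(=O)N4CCN(c5ccccc5)C(C)C4)cc3)[nH]c2c1=O` returns in this assay only the limit > 1000 nM. Within the data shown here, all three values sit at the limit of > 1000 nM in this assay, at which 3 of the 3 values shown sit, so compound 1 cannot be placed against the other two, and no step between measured compounds is available. Compound 4 `CCCn1c(=O)[nH]c2nc(-c3ccc(S(=O)(=O)N4CCN(C(C)c5ccccc5)CC4)cc3)[nH]c2c1=O` differs from compound 1 by 1-phenylethyl in place of 2-methylphenyl on an amine nitrogen in a ring. Among the measured compounds shown here, with no measured step to lean on, the expected step is a step that the limit leaves unreadable from compound 1 to compound 4, within the scatter. Compound 4 is therefore expected to give in this assay about 1500 nM, with a range from 500 nM to 5000 nM, most probably again as a limit rather than a number.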

Compound 4, inhibition constant: > 1000 nM
Compound 4 gave a limit, no number; the forecaster's own chance of this, stated with the estimate: 70%; the middle value lies beyond the limit too.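

No step can be read from compound 1 to compound 4, as both return only a limit: the limit of > 1000 nM in this assay, at which 4 of the 4 values shown sit. The compounds shown leave open what number any of the four would give in this assay and whether 1-phenylethyl and 2-methylphenyl differ at all.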